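The source may report more compounds than this note shows. Statements on the series, on what has been measured and on what is new or still open speak of the compounds shown alone.

Of the compounds shown here, three have numbers so far. Compound 1 `CCCCCCCCCO[C@@H]1[C@@H](N)[C@@H](OCC(O)CNCCCO)O[C@H](CN)[C@H]1OCCCCCCCCC` gives 89.9% in a toxicity assay on the whole organism (J774 cells) for cytotoxicity, with Mus musculus as the target, read by MTT assay, with a stated time of 24 h, tested at 10 uM; on this read-out higher numbers stand for a weaker effect at the one concentration tested and lower numbers for a stronger effect; compound 2 `C=CCO[C@H]1O[C@H](CN)[C@@H](OCc2ccc3ccccc3c2)[C@H](OCc2ccc3ccccc3c2)[C@H]1N` gives 86.9%, and compound 3 `NC[C@H]1O[C@H](O[C@H]2[C@H](O)[C@@H](O)[C@H](N)C[C@@H]2N)[C@H](N)[C@@H](OCCCc2ccc3ccccc3c2)[C@@H]1OCCCc1ccc2ccccc2c1` gives 87.7%. The three numbers lie within the usual scatter of one another, so compound 1 cannot be set apart from the other two; all three show only a weak effect at the one concentration tested. For the measured compounds named here, no pair of measured compounds differs in a single place, so no measured step is known. Compound 4 `CCCCCCCCCO[C@@H]1[C@@H](N)[C@@H](OC[C@H](O)CN)O[C@H](CN)[C@H]1OCCCCCCCCC` is compound 1 with 2-amino-1-hydroxyethyl in place of 1-hydroxy-2-((3-hydroxypropyl)amino)ethyl on a saturated chain carbon bound to an oxygen on a saturated carbon. Going by the values given here, with no step to rest on, the number for compound 4 is expected to stay close to that of compound 1, the expected step being a number 1.9 percentage points lower from compound 1 to compound 4 (within the scatter), not beyond the scatter. Compound 4 is expected to give 88%, within a range from 77% to 97%.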

Compound 4, a percentage reported as activity, at one concentration (the size of the read-out at that concentration, not a potency): 88%
Compound 4: the middle estimate sits on the measured number at the digits printed, and the stated range covers the measured number.
By their numbers in this assay, from the lowest: compounds 2, 3, 4 and 1 (each within the scatter of the next).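

For the compounds shown here, replacing 1-hydroxy-2-((3-hydroxypropyl)amino)ethyl with 2-amino-1-hydroxyethyl on a saturated chain carbon bound to an oxygen on a saturated carbon gives in this assay a number 1.9 percentage points lower from compound 1 to compound 4 (within the scatter) and is the only single-place step so far. This position therefore accepts a side group of 4 heavy atoms in place of one of 8 without a change that can be told from the scatter. No evidence bears on this result.

On these data alone, whether a carboxylic acid or a piperidine at this place would give a number beyond the scatter remains open.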